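Compound 3 in the series: expected effect of removing chloro

The compounds below may be only part of what the source reports. "The series", "measured", "known", "first", "only" and "open" are said of these compounds alone.

Measured so far:
compound 1 `Cc1ccccc1Nc1nc(C)c(C(=O)/C=C/c2ccccc2)s1` — > 25000 nM (a limit of the assay, not a number)
compound 2 `Cc1ccc(Nc2nc(C)c(C(=O)/C=C/c3ccccc3Cl)s2)cc1` — > 25000 nM (a limit of the assay, not a number)

In a functional assay on PC-3 cells (Homo sapiens) for cytotoxicity, read by MTT assay (a lower number here means a stronger inhibitor, a higher number a weaker inhibitor), compound 1 reaches only a limit, > 25000 nM. Compound 2 likewise reaches only a limit in this assay, > 25000 nM. For the measured compounds named here, compound 2 therefore stands at the limit of > 25000 nM in this assay, at which 2 of the 2 values shown sit; neither value gives a number to compare, and no step between measured compounds can be drawn.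

Compound 3 `Cc1ccc(Nc2nc(C)c(C(=O)/C=C/c3ccccc3)s2)cc1` is not yet measured. It differs from compound 2 by hydrogen in place of chloro on an aromatic carbon. Compound 1, which carries the unsubstituted phenyl on the same side, also sits at the limit.

Given that both measured compounds sit at the limit, the step from compound 2 to compound 3 is expected to be none beyond the scatter, a step that the limit leaves unreadable from compound 2 to compound 3. Compound 3 is accordingly estimated at 40000 nM, within 10000 nM to 160000 nM, and a further limit rather than a number is the likely read-out.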

Compound 3, half-maximal inhibitory concentration: > 25000 nM
Compound 3: no number, only a limit; the forecaster's own chance of this, stated with the estimate: 80%; the middle value does not contradict the limit.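

Compound 3 reads only as a limit in this assay, as do compound 1 and compound 2, so no step from either of them to compound 3 can be read: the limit of > 25000 nM in this assay, at which 3 of the 3 values shown sit.

The compounds shown leave open whether chloro, or 4-methylphenyl in place of 2-methylphenyl, changes anything in this assay.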